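The source may hold more compounds than are shown below. What is called first, only, known or untested is meant among the compounds shown, and "the series" means these compounds.

Measured in an ADME assay on J774 cells (Mus musculus) for cytotoxicity, read by MTT assay, with a stated time of 48 h; on this read-out lower numbers stand for stronger inhibition and higher numbers for weaker inhibition:
- Compound 1 `N=C(N)N/N=C\c1ccccc1OCc1ccc2no[n+]([O-])c2c1`: < 100 uM (a limit)
- Compound 2 `NC(=S)N/N=C\c1ccccc1OCc1ccc2no[n+]([O-])c2c1`: < 100 uM (a limit)
- Compound 3 `C=CCNC(=S)N/N=C\c1ccccc1OCc1ccc2no[n+]([O-])c2c1`: 138 uM

Among the measured compounds shown here, compound 3 gives 138 uM, the only true number in the set. Compound 1 is recorded at < 100 uM, which is a limit and not a number. Compound 2 is recorded at < 100 uM, which is also a limit. As far as these compounds go, the order of the three therefore stays open, as the limit of < 100 uM in this assay, at which 2 of the 3 values shown sit, shows.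

Compound 4 `NC(=O)N/N=C\c1ccccc1OCc1ccc2no[n+]([O-])c2c1` has not been measured yet. It differs from compound 3 by a group of 3 heavy atoms (1 carbon, 1 nitrogen, 1 oxygen; no ring) in place of a group of 6 heavy atoms (4 carbon, 1 nitrogen, 1 sulfur; no ring), on an amine nitrogen. Like compound 1 and compound 2, it carries no allyl.

For the measured compounds named here, two measured steps bear on this change: an at least 1.3-fold higher number from compound 2 to compound 3 (0.13 log units; that floor lies within the scatter) and an at least 1.3-fold higher number from compound 1 to compound 3 (0.13 log units; that floor lies within the scatter). Each gives only a minimum size, and the step that the two limits leave unreadable from compound 1 to compound 2 adds nothing on size. A small move to a lower number in this assay is therefore expected, probably not beyond the scatter. The estimated step is a 1.5-fold lower number from compound 3 to compound 4 (0.19 log units; within the scatter). For compound 4 the expected value is 90 uM, with an estimated range of 35 uM to 220 uM.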

Compound 4, concentration for 50% inhibition: < 100 uM
Compound 4 gave a limit, no number (the forecaster's own chance of this, stated with the estimate: 45%); the middle value does not contradict the limit.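

Compound 4 is recorded at < 100 uM in this assay, which is a limit and not a number. Carbamoyl on the amine nitrogen, in place of the group of 6 heavy atoms in compound 3, gives an at least 1.3-fold lower number from compound 3 to compound 4 (0.13 log units; that floor lies within the scatter), so this change shows only a small minimum size. The steps from compound 1 and from compound 2 to compound 4 cannot be read, because both ends of each are limits: the limit of < 100 uM in this assay, at which 3 of the 4 values shown sit.

The order of compound 1, compound 2 and compound 4 therefore stays open, and among the compounds shown, only compound 3, which carries the allyl, has a true number. As far as these compounds go, whether an allyl or a longer chain such as butyl on the carbamoyl nitrogen would give a readable number also remains unknown.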